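Adding one methyl to compound 3

The source may report more compounds than this note shows. Statements on the series, on what has been measured and on what is new or still open speak of the compounds shown alone.

Values in a functional assay on CCRF-CEM cells (Homo sapiens), read by MTT assay, with a stated time of 72 h; on this read-out higher numbers stand for weaker inhibition and lower numbers for stronger inhibition:
- compound 1 `CSc1ncnc2c1c(-c1ccsc1)cn2[C@@H]1O[C@H](CO)[C@@H](O)[C@H]1O`: > 20000 nM
- compound 2 `CNc1ncnc2c1c(-c1ccco1)cn2[C@@H]1O[C@H](CO)[C@@H](O)[C@H]1O`: 180 nM
- compound 3 `CNc1ncnc2c1c(-c1ccsc1)cn2[C@@H]1O[C@H](CO)[C@@H](O)[C@H]1O`: > 20000 nM

Compound 3 gives > 20000 nM in this assay, which is a limit of the assay and not a number. Compound 1 gives > 20000 nM, and this too is a limit. Compound 3 therefore sits at the limit of > 20000 nM in this assay, at which 2 of the 3 values shown sit, and compound 2 alone has a true number.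

Compound 4 `CN(C)c1ncnc2c1c(-c1ccsc1)cn2[C@@H]1O[C@H](CO)[C@@H](O)[C@H]1O` differs from compound 3 by one change: methyl in place of hydrogen on a nitrogen on an aromatic ring, or methylamino to dimethylamino (methyl in place of hydrogen on a nitrogen on an aromatic ring).

For the measured compounds named here, no measured step shows this change directly, and two bear on it only loosely. Methylamino in place of methylsulfanyl gave a step that the two limits leave unreadable from compound 1 to compound 3. Thiophen-3-yl in place of furan-2-yl gave an at least 110-fold higher number from compound 2 to compound 3 (2.04 log units; beyond the scatter), a large step, but compound 4 keeps the thiophen-3-yl group. Compound 1 has that group too, and compound 3 sits at the limit of > 20000 nM in this assay, at which 2 of the 3 values shown sit, so no readable step in either direction is expected in this assay, and compound 4 will probably report only a limit as well. The expected step is a step that the limit leaves unreadable from compound 3 to compound 4. For compound 4 the estimate is 25000 nM, with an expected range from 8000 nM to 60000 nM.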

Compound 4, half-maximal inhibitory concentration: 3480 nM
Estimate against measurement, compound 4: 7.2-fold (0.86 log units) above; the whole stated range lies above it.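

In this assay, changing methylamino to dimethylamino gives an at least 5.7-fold lower number from compound 3 to compound 4 (0.75 log units; beyond the scatter), so this nitrogen on an aromatic ring is a place where one added methyl changes the read-out, even with the thiophen-3-yl group kept. Dimethylamino in place of methylsulfanyl on an aromatic carbon gives an at least 5.7-fold lower number from compound 1 to compound 4 (0.75 log units; beyond the scatter), which makes compound 4 the first thiophen-3-yl compound here with a true number rather than a limit. Both steps can be given only as minimum sizes because their starting compounds stand at a limit: the limit of > 20000 nM in this assay, at which 2 of the 4 values shown sit.

Going by these compounds, it remains open whether the lower number depends on methyl itself, or whether a longer chain such as ethyl on this nitrogen, or a ring amine such as pyrrolidine in place of dimethylamino, would lower it as well or further. Also open, on these data alone, is what the same added methyl does when furan-2-yl takes the place of thiophen-3-yl, as in compound 2, where the nitrogen still carries its hydrogen.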